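The source may report more compounds than this note shows. Statements on the series, on what has been measured and on what is new or still open speak of the compounds shown alone.

Compound 2 `N#CC1=C(N)Oc2c(N)cc3nc4ccccc4nc3c2C12C(=O)N(Cc1cnnn1-c1cc(Cl)ccc1Cl)c1ccccc12` carries a 2,5-dichlorophenyl on an aromatic nitrogen of the shared core. Within the data shown here, in a functional assay on A549 cells (Homo sapiens) for antiproliferative activity, read by MTT assay, with a stated time of 48 h (on this read-out higher numbers stand for weaker inhibition and lower numbers for stronger inhibition), compound 2 gives 10900 nM, the only plain number among the two measured compounds. Its partner, compound 1 `N#CC1=C(N)Oc2c(N)cc3nc4ccccc4nc3c2C12C(=O)N(Cc1cnnn1-c1ccc(Cl)cc1Cl)c1ccccc12`, differs from it only in bearing a 2,4-dichlorophenyl at the same place. In this assay compound 1 reaches only a limit, > 50000 nM. Among the measured compounds shown here, the single measured step, an at least 4.5-fold lower number from compound 1 to compound 2 (0.66 log units; beyond the scatter), is thus bounded by the limit of > 50000 nM in this assay, at which 1 of the 2 values shown sits, so its full size is not known.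

Compound 3 `N#CC1=C(N)Oc2c(N)cc3nc4ccccc4nc3c2C12C(=O)N(Cc1cnnn1-c1c(Cl)cc(Cl)cc1Cl)c1ccccc12` is the next variant: 2,4,6-trichlorophenyl in place of 2,5-dichlorophenyl on an aromatic nitrogen. Its 2,4,6-trichlorophenyl resembles the 2,4-dichlorophenyl of compound 1 more than the 2,5-dichlorophenyl of compound 2. For the measured compounds named here, only the step from compound 1 to compound 2 bears on this change, and it shows that rearranging chlorines on this ring moves the result beyond the scatter. The number for compound 3 in this assay is therefore expected to rise, by about a 2.3-fold higher number from compound 2 to compound 3 (0.36 log units; beyond the scatter). A limit, as with compound 1, is a real possibility. The estimate for compound 3 is 25000 nM, within 8000 nM to 80000 nM.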

Compound 3, half-maximal inhibitory concentration: > 50000 nM
Compound 3 was reported as a limit (the forecaster's own chance of this, stated with the estimate: 35%); middle value at least 2.0-fold (0.30 log units) from the limit.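

Replacing the 2,5-dichlorophenyl with the 2,4,6-trichlorophenyl on the aromatic nitrogen gives an at least 4.5-fold higher number from compound 2 to compound 3 (0.66 log units; beyond the scatter) in this assay, so this second change of chlorine pattern also moves the result beyond the scatter, this time towards weaker inhibition. Among these compounds, compound 3 gives > 50000 nM, which is a limit and not a number, so the size of that step is only bounded and compound 2 remains the only one of the three compounds with a plain value. The 2,4-dichlorophenyl and the 2,4,6-trichlorophenyl thus both end at the limit, and the step between the two compounds that carry them, a chloro in place of hydrogen, cannot be read: the limit of > 50000 nM in this assay, at which 2 of the 3 values shown sit.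

The compounds shown leave open how much weaker compound 1 and compound 3 really are, and whether either differs from the other at all. They also leave open whether a plain phenyl, a single chloro, a methoxy group or an amine on this ring would give a lower number than the 2,5-dichlorophenyl of compound 2.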